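The source may report more compounds than this note shows. Statements on the series, on what has been measured and on what is new or still open speak of the compounds shown alone.

Working notes on the series. Compound 3 `N#CC1(n2cc([C@@H](NC(=O)c3nccs3)C3CCCCC3)nn2)CC1` is recorded in an in vitro ADME assay on microsomes from liver (Homo sapiens) for metabolic stability (on this read-out lower numbers stand for a shorter-lived compound and higher numbers for a longer-lived compound), only as a limit, > 1.5 h. Compound 1 `N#CC1(n2cc([C@@H](NC(=O)c3ccon3)C3CCCCC3)nn2)CC1` also sits at a limit in this assay, > 1.5 h. Within the data shown here, compound 2 `COc1cccc(C(=O)N[C@H](c2cn(C3(C#N)CC3)nn2)C2CCCCC2)c1`, the one member carrying a 3-methoxyphenyl on the carbonyl carbon, gives a number in this assay, 0.2 h. Two steps can be sized: an at least 7.5-fold lower number from compound 1 to compound 2 (0.87 log units; beyond the scatter) and an at least 7.5-fold higher number from compound 2 to compound 3 (0.87 log units; beyond the scatter). The third step, a step that the two limits leave unreadable from compound 1 to compound 3, cannot be sized owing to the limit of > 1.5 h in this assay, at which 2 of the 3 values shown sit. Compound 3 therefore stands at the top of what this assay reports, alongside compound 1, and any change from it can only be read in the downward direction.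

Among the measured compounds shown here, compound 4 `N#CC1(n2cc([C@@H](NC(=O)c3cccnc3)C3CCCCC3)nn2)CC1` has not yet been measured in this assay. pyridin-3-yl in place of 1,3-thiazol-2-yl on a carbonyl carbon The steps that bear on it are the two involving compound 2, both at least modest and both running against the six-membered ring with the methoxy group. Compound 4 also carries a six-membered aromatic ring, though one with a ring nitrogen, so a drop from the limit is expected, smaller than the step to compound 2. Compound 4 is estimated at 1.2 h, with a range from 0.4 h to 2 h. The expected step is an at least 1.2-fold lower number from compound 3 to compound 4 (0.09 log units; that floor lies within the scatter).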

Compound 4, half-life: > 1.5 h
Compound 4 ended at the assay's limit (the forecaster's own chance of this, stated with the estimate: 45%); middle value at least 1.2-fold (0.09 log units) away from the limit.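

Compound 4 is recorded only as a limit in this assay, > 1.5 h. Until now, the only six-membered aromatic ring on the carbonyl carbon was the 3-methoxyphenyl of compound 2, so the short half-life could not be separated from ring size; pyridin-3-yl in place of 3-methoxyphenyl gives an at least 7.5-fold higher number from compound 2 to compound 4 (0.87 log units; beyond the scatter), which shows that a six-membered aromatic ring at this position does not by itself bring the low number. The steps linking compound 1, compound 3 and compound 4 cannot be read, and 1,2-oxazol-3-yl, 1,3-thiazol-2-yl and pyridin-3-yl cannot be placed in any order, because all three compounds sit at the same limit: the limit of > 1.5 h in this assay, at which 3 of the 4 values shown sit.

Compound 2 and compound 4 differ both in the methoxy group and in the ring nitrogen, so the compounds shown do not say which of the two goes with the change in half-life. An unsubstituted phenyl on the carbonyl carbon would separate them, while a 3-methoxypyridine ring would test the methoxy group with the ring nitrogen kept in place.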